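A Phenyl Swap in a Tightly Grouped Series

The source may hold more compounds than are shown below. What is called first, only, known or untested is meant among the compounds shown, and "the series" means these compounds.

In a functional assay on SK-OV-3 cells (Homo sapiens) for antiproliferative activity, read by MTT assay, with a stated time of 72 h (on this read-out higher numbers stand for weaker inhibition and lower numbers for stronger inhibition), compound 1 (`O=C(CCc1cccc2c1B(O)OC2)Nc1cccc(Br)c1`) gives 540 nM and compound 2 (`CC(C)c1cccc(NC(=O)CCc2cccc3c2B(O)OC3)c1`) gives 510 nM, while compound 3 (`O=C(CCc1cccc2c1B(O)OC2)Nc1cccc(-c2cccc(Cl)c2)c1`) gives 300 nM and so stands within the scatter of both. Compound 4 (`COc1ccc(-c2cccc(NC(=O)CCc3cccc4c3B(O)OC4)c2)cc1`) differs from compound 3 in one place (4-methoxyphenyl in place of 3-chlorophenyl on an aromatic carbon), with 4-methoxyphenyl in place of 3-chlorophenyl on an aromatic carbon, meta to a large group. The measured steps at that carbon (a 1.1-fold lower number from compound 1 to compound 2 (0.02 log units; within the scatter); a 1.8-fold lower number from compound 1 to compound 3 (0.26 log units; within the scatter); a 1.7-fold lower number from compound 2 to compound 3 (0.23 log units; within the scatter)) all lie within the scatter. None of them swaps one phenyl group for another, so their guidance is indirect. No step beyond the scatter is expected in this assay here. The expected step is small (a 1.2-fold higher number from compound 3 to compound 4 (0.07 log units; within the scatter)). Compound 4 is estimated at 350 nM with an expected range (130 nM to 900 nM).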

Compound 4, half-maximal inhibitory concentration: 48 nM
Compound 4: the middle estimate sits 7.3-fold (0.86 log units) above what was measured; the measured number lies below the stated range.
By their numbers in this assay, from the lowest: compound 4; then compounds 3, 2 and 1 (each within the scatter of the next).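

In this assay, this aromatic carbon now separates compounds, which compound 1, compound 2 and compound 3 did not show: the new group gives a 6.3-fold lower number from compound 3 to compound 4 (0.80 log units; beyond the scatter), an 11-fold lower number from compound 2 to compound 4 (1.03 log units; beyond the scatter) and an 11-fold lower number from compound 1 to compound 4 (1.05 log units; beyond the scatter). Having a phenyl group here is therefore not enough, as 3-chlorophenyl and 4-methoxyphenyl differ beyond the scatter. Nothing available explains this step. Going by these compounds, whether the difference follows the methoxy group or its place on the phenyl group remains open. A 3-methoxyphenyl, 4-chlorophenyl or 4-hydroxyphenyl group would bear on that question.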